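Cyclopropyl in place of tert-butyl on the amide nitrogen

The compounds below may be only part of what the source reports. "The series", "measured", "known", "first", "only" and "open" are said of these compounds alone.

Of the compounds shown here, three sharing one core have been measured in an in vitro assay on BaF3 cells for displacement of a labelled ligand from C-X-C chemokine receptor type 3 (Homo sapiens); a lower number here means a stronger inhibitor, a higher number a weaker inhibitor. Compound 1 `CC[C@H]1CN(c2nc(N)c(C(N)=O)nc2Cl)CCN1C1CCN(Cc2ccc(C#N)cc2)CC1` gives 8.5 nM. Compound 2 `CC[C@H]1CN(c2ncc(C(N)=O)nc2Cl)CCN1C1CCN(C(=O)c2ccc(Cl)nc2N)CC1` gives 2.5 nM. Compound 3 `CC[C@H]1CN(c2ncc(C(=O)NC(C)(C)C)nc2Cl)CCN1C1CCN(C(=O)c2ccc(Cl)nc2N)CC1` gives 1.5 nM, the lowest of the three numbers. Its number and that of compound 2 lie within the scatter of each other, while compound 1 stands apart, beyond the scatter. Between compound 2 and its tert-butyl partner, the tert-butyl entering for hydrogen on an amide-type nitrogen gave a 1.7-fold lower number from compound 2 to compound 3 (0.22 log units; within the scatter).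

Compound 4 `CC[C@H]1CN(c2ncc(C(=O)NC3CC3)nc2Cl)CCN1C1CCN(C(=O)c2ccc(Cl)nc2N)CC1` has not yet been measured. It differs from compound 3 by cyclopropyl in place of tert-butyl on an amide-type nitrogen. Among the compounds with values here, the only measured step that touches this position is the one just described, and it stayed within the scatter: adding a group to that amide nitrogen did not move the number in a way that can be trusted. Exchanging one such group for another is therefore expected to change little. The step of a 1.3-fold higher number from compound 3 to compound 4 (0.12 log units; within the scatter) is the expected outcome, meaning nothing beyond the scatter in either direction. Compound 4 is expected to give 2 nM in this assay, with a range from 0.8 nM to 5 nM.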

Compound 4, half-maximal inhibitory concentration: 1.2 nM
Compound 4: the middle estimate sits 1.7-fold (0.22 log units) above what was measured; low and high end bracket the measured number.
By their numbers in this assay, from the lowest: compounds 4, 3 and 2 (each within the scatter of the next, the first and the last beyond it); then compound 1.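

In this assay, replacing tert-butyl with cyclopropyl on the amide nitrogen gave a 1.3-fold lower number from compound 3 to compound 4 (0.10 log units; within the scatter), so two different carbon groups, one holding a three-membered ring and one holding no ring, cannot be told apart at this position. Against hydrogen on the same nitrogen, cyclopropyl gave a 2.1-fold lower number from compound 2 to compound 4 (0.32 log units; beyond the scatter), the first step at this position to pass beyond the scatter, although the step is modest and compound 3 and compound 4 remain within the scatter of each other, so it marks no real difference between the two groups. Nothing measured here explains why the numbers fall where they do.

The compounds shown carry only hydrogen, tert-butyl or cyclopropyl on this nitrogen, so it remains open whether a longer chain such as n-butyl, or a group bearing an amine or a carboxylic acid, would keep the number in the same range. As far as these compounds go, it is also open whether cyclopropyl on this nitrogen would give a similar step on the other parts of compound 1, which differs from the rest in more than one place.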